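Cytotoxicity notes: aryl change at the saturated ring carbon

The source may report more compounds than this note shows. Statements on the series, on what has been measured and on what is new or still open speak of the compounds shown alone.

Measured compounds:
compound 1, `Cc1ccc(C2C(C#N)=C(N)N(c3ccc(S(N)(=O)=O)cc3)C3=C2CCCC3)cc1`: 90%
compound 2, `N#CC1=C(N)N(c2ccc(S(N)(=O)=O)cc2)C2=C(CCCC2)C1c1ccc([N+](=O)[O-])cc1`: 20%

In a functional assay on Ehrlich cells (Mus musculus) for cytotoxicity, read by trypan blue exclusion, with a stated time of 2 h, tested at 100 ug/mL (on this read-out higher numbers stand for a stronger effect at the one concentration tested and lower numbers for a weaker effect), compound 1 gives 90%. In this assay, for the measured compounds named here, compound 2 gives 20%, the lowest of the two numbers, and the only measured step, a number 70 percentage points lower from compound 1 to compound 2 (beyond the scatter), is large. Compound 3, `N#CC1=C(N)N(c2ccc(S(N)(=O)=O)cc2)C2=C(CCCC2)C1c1c(O)ccc2ccccc12`, is yet to be measured. Its change from compound 2 is 2-hydroxynaphthalen-1-yl in place of 4-nitrophenyl on a saturated ring carbon. Going by the values given here, no measured step covers this exchange, so there is no direct guide. Among the compounds with values here, the one step that exists shows that exchanging the group on that saturated ring carbon can move this assay far, and compound 3 no longer carries the nitro group seen in compound 2. A rise from compound 2 is therefore expected, with the size left open. For compound 3 the estimated value is 55%, with a range from 20% to 90%. This estimate means an expected step of a number 35 percentage points higher from compound 2 to compound 3 (beyond the scatter).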

Compound 3, a percentage reported as activity, at one concentration (the size of the read-out at that concentration, not a potency): 50%
Beside the measured number, compound 3's estimate is 5 percentage points above it; the measured number falls inside the stated range.
By their numbers in this assay, from the lowest: compound 2; then compound 3; then compound 1.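

Notes on the saturated ring carbon: in this assay, 2-hydroxynaphthalen-1-yl in place of 4-nitrophenyl gives a number 30 percentage points higher from compound 2 to compound 3 (beyond the scatter), while the same group in place of 4-methylphenyl gives a number 40 percentage points lower from compound 1 to compound 3 (beyond the scatter). A third aryl group at this position therefore gives an intermediate level rather than matching either earlier compound, so the read-out here is graded across the three compounds and not split into two levels. No measured information on these compounds accounts for this order.

The 2-hydroxynaphthalen-1-yl group brings the second aromatic ring and the hydroxyl together, so the contribution of each stays unresolved. Unsubstituted naphthalen-1-yl and 4-hydroxyphenyl at the same carbon would separate the two, and 4-aminophenyl would extend the para-free comparison of single-ring groups.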